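Cytotoxicity notes: aromatic substituents on a shared core

The source may hold more compounds than are shown below. What is called first, only, known or untested is meant among the compounds shown, and "the series" means these compounds.

Measured compounds:
compound 1 `O=C(N/N=C/c1ccccc1)c1cnccn1`: 100%
compound 2 `CCOc1ccc(/C=N/NC(=O)c2cnccn2)cc1`: 100%

In an ADME assay on J774 cells (Mus musculus) for cytotoxicity, read by MTT assay, with a stated time of 48 h, tested at 150 ug/mL (a lower number here means a stronger effect, a higher number a weaker effect of the compound at the concentration tested), compound 1 gives 100% and stands level with compound 2, which gives 100%. Going by the values given here, the one measured step, no change at the digits printed from compound 1 to compound 2 (within the scatter), adds a substituent on an aromatic carbon of the shared core and leaves the read-out unmoved.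

Compound 3 `N#Cc1ccccc1/C=N/NC(=O)c1cnccn1` differs from compound 1 in one place: cyano in place of hydrogen on an aromatic carbon. Among the compounds with values here, this step has no direct precedent; the only related step is the one from compound 1 to compound 2, which showed no change. On that basis no shift beyond the scatter is expected, no change at the digits printed from compound 1 to compound 3 (within the scatter). Compound 3 is therefore expected to give 100%, with a range from 88% to 108%.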

Compound 3, a percentage reported as activity, at one concentration (the size of the read-out at that concentration, not a potency): 70%
The estimate for compound 3 lay 30 percentage points above the measured number, outside the stated range (below it).
By their numbers in this assay, from the lowest: compound 3; then compounds 1 and 2 (each within the scatter of the next).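

With cyano in place of hydrogen on an aromatic carbon, ortho to a large group, this assay shows a number 30 percentage points lower from compound 1 to compound 3 (beyond the scatter) and gives the series its first step beyond the scatter. Substitution on this aromatic ring of the shared core is therefore not always silent in this read-out, and a small group with no ring is enough to move it. No measurement at hand accounts for this shift.

As far as these compounds go, whether the shift follows from the cyano group itself or from its place remains open. An amine or a carboxylic acid on the same carbon, or cyano elsewhere on the ring, would separate the two.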